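Swapping trifluoromethyl for methoxy in a cytotoxicity series

The source may hold more compounds than are shown below. What is called first, only, known or untested is meant among the compounds shown, and "the series" means these compounds.

Of the compounds shown here, three have been tested so far in a toxicity assay on cells (Macrophage, Mus musculus, strain BALB/c) for cytotoxicity, read by MTT assay; a lower number here means a stronger inhibitor, a higher number a weaker inhibitor. Compound 1 `C=CCOc1cc(OC)c(C(=O)/C=C/c2ccc(F)cc2)c(OCC=C)c1` gives 13800 nM. Compound 2 `COc1cc(O)cc(O)c1C(=O)/C=C/c1ccc(C(F)(F)F)cc1` gives 17100 nM, and compound 3 `COc1cccc(/C=C/C(=O)c2c(O)cc(O)cc2OC)c1` gives 17600 nM. Compound 2 stands second highest of these three numbers, yet its gap to compound 3 and its gap to compound 1 both lie within the usual scatter of repeated measurements, so the three values cannot be ranked against one another.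

Compound 4 `COc1ccc(/C=C/C(=O)c2c(O)cc(O)cc2OC)cc1` has not yet been measured in this assay. Compared with compound 2 the change is methoxy in place of trifluoromethyl on an aromatic carbon, and the new group sits on an aromatic carbon of a six-membered aromatic ring of carbon only, para to a large group. For the measured compounds named here, no measured pair in this set shows the effect of such a change on its own, so the expectation rests on how flat the numbers are across compounds 1, 2 and 3. The step from compound 2 to compound 4 is expected to be a 1.0-fold lower number from compound 2 to compound 4 (0.00 log units; within the scatter), in no particular direction and not beyond the scatter. Compound 4 is therefore estimated at 17000 nM, within a range from 8000 nM to 36000 nM.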

Compound 4, half-maximal inhibitory concentration: 166000 nM
Compound 4: middle estimate off by 9.8-fold (0.99 log units), on the low side, and the stated range ends below it.
By their numbers in this assay, from the lowest: compounds 1, 2 and 3 (each within the scatter of the next); then compound 4.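

In this assay, for the compounds shown here, this aromatic carbon turns out not to be indifferent: methoxy in place of trifluoromethyl gives a 9.7-fold higher number from compound 2 to compound 4 (0.99 log units; beyond the scatter) and is the first step in this set to pass beyond the scatter. The step points toward weaker inhibition, so compound 4 acts on the cells less strongly than compound 2. The close numbers of compounds 1, 2 and 3 gave no sign that a single group at this place could matter so much, and nothing measured here accounts for the size of the step.

One pair cannot tell whether the number follows trifluoromethyl leaving or methoxy entering. A methyl group, a chlorine atom or an amine on the same aromatic carbon would help separate these two readings.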